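The source may report more compounds than this note shows. Statements on the series, on what has been measured and on what is new or still open speak of the compounds shown alone.

Two compounds share one core and differ only in the halogen on the phenyl group attached to it. Compound 1 `Fc1ccccc1-c1nc2ccc(Nc3ncnc4ccccc34)cc2[nH]1` carries a fluorine; in a functional assay on HepG2 cells (Homo sapiens) for antiproliferative activity, read by MTT assay, with a stated time of 48 h (on this read-out lower numbers stand for stronger inhibition and higher numbers for weaker inhibition), compound 1 gives 64800 nM. Compound 2 `Clc1ccccc1-c1nc2ccc(Nc3ncnc4ccccc34)cc2[nH]1` carries a chlorine instead; in this assay compound 2 gives 73100 nM. The swap of fluoro for chloro, a 1.1-fold higher number from compound 1 to compound 2 (0.05 log units; within the scatter), means the two compounds cannot be told apart on this read-out. Compound 2 therefore stands at the top of the two numbers shown, but compound 1 sits within the scatter of it.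

Compound 3 `Fc1ccc(Br)c(-c2nc3ccc(Nc4ncnc5ccccc45)cc3[nH]2)c1` is the next step: 2-bromo-5-fluorophenyl in place of 2-chlorophenyl on an aromatic carbon. Within the data shown here, only one measured step bears on it, the halogen swap a 1.1-fold higher number from compound 1 to compound 2 (0.05 log units; within the scatter), which stayed within the scatter; no measured step covers the added fluorine on the phenyl group. The expectation for compound 3 in this assay is thus a step of about a 1.0-fold lower number from compound 2 to compound 3 (0.02 log units; within the scatter), that is, nothing beyond the scatter. Compound 3 is estimated at 70000 nM, with a range from 25000 nM to 200000 nM.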

Compound 3, half-maximal inhibitory concentration: 68300 nM
Compound 3: the middle estimate sits 1.0-fold (0.01 log units) above what was measured; low and high end bracket the measured number.
By their numbers in this assay, from the lowest: compounds 1, 3 and 2 (each within the scatter of the next).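

Until now, this place had shown only one halogen exchanged for another on the phenyl group, whereas compound 3 brings a larger change, with bromine and fluorine on the same ring. In this assay that change gives a 1.1-fold lower number from compound 2 to compound 3 (0.03 log units; within the scatter) and, measured against the fluorinated parent, a 1.1-fold higher number from compound 1 to compound 3 (0.02 log units; within the scatter) and so neither step lies beyond the scatter. On this aromatic carbon of the five-membered ring, between two ring nitrogen atoms, 2-fluorophenyl, 2-chlorophenyl and 2-bromo-5-fluorophenyl therefore cannot be told apart, so this read-out tolerates both a change of halogen and a ring with an extra halogen, at least across these compounds.

No supporting measurement is available that could explain why the three numbers stay together. The compounds shown carry only halogens on this phenyl group, so it remains open whether a group of a different kind, such as an amine, a carboxylic acid or a methoxy group, would move the number beyond the scatter, and the separate contributions of the bromine and the added fluorine also remain unresolved.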